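A few compounds are considered here, and "the series" means these few. Any claim that something is new, unique, unknown or untested is made for them only; others in the source may bear on it.

Measured compounds in an ADME assay on microsomes from liver (Homo sapiens) for metabolic stability, read by LC-MS, using NADPH, tested at 5 uM; a lower number here means that the compound disappears faster, a higher number that the compound lasts longer:
compound 1 `Cc1cc(S(=O)(=O)/N=C(\N)N/N=C/C#Cc2ccccc2)c(SCc2ccccc2)cc1Cl` gives 0.469 h
compound 2 `C/C(C#Cc1ccccc1)=N\N/C(N)=N/S(=O)(=O)c1cc(C)c(Cl)cc1SCc1ccccc1` gives 0.466 h
compound 3 `Cc1cc(S(=O)(=O)/N=C(\N)N/N=C/C#Cc2ccccc2)c(SCc2ccccc2Cl)cc1Cl` gives 0.254 h

Compound 4 `C/C(C#Cc1ccccc1)=N\N/C(N)=N/S(=O)(=O)c1cc(C)c(Cl)cc1SCc1ccccc1Cl` is not yet measured in this assay. It differs from compound 3 by a group of 11 heavy atoms (10 carbon, 1 nitrogen; one six-membered aromatic ring of carbon only) in place of a group of 10 heavy atoms (9 carbon, 1 nitrogen; one six-membered aromatic ring of carbon only), on an amine nitrogen. The same change, made once before among these compounds, is a group of 11 heavy atoms (10 carbon, 1 nitrogen; one six-membered aromatic ring of carbon only) in place of a group of 10 heavy atoms (9 carbon, 1 nitrogen; one six-membered aromatic ring of carbon only), on an amine nitrogen, and there it gave a 1.0-fold lower number from compound 1 to compound 2 (0.00 log units; within the scatter). The two cores differ by chloro in place of hydrogen on an aromatic carbon, which on its own gave a 1.8-fold lower number from compound 1 to compound 3 (0.27 log units; within the scatter). The place of the change is worded identically in both cases, so the change is taken as the same one.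

With a single precedent that left the half-life unchanged, compound 4 is expected to sit close to compound 3, the estimated step being a 1.0-fold lower number from compound 3 to compound 4 (0.01 log units; within the scatter), because compound 1 to compound 2 showed a 1.0-fold lower number from compound 1 to compound 2 (0.00 log units; within the scatter). Compound 4 is estimated at 0.25 h, with a range from 0.13 h to 0.5 h.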

Compound 4, half-life: 1.42 h
Estimate against measurement, compound 4: 5.7-fold (0.75 log units) below; the measured number lies above the stated range.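

In this assay, the group of 11 heavy atoms in place of the group of 10 heavy atoms on an amine nitrogen does not carry over unchanged between cores, giving a 5.6-fold higher number from compound 3 to compound 4 (0.75 log units; beyond the scatter) on the chlorinated core: the same change on two cores in this assay, a 1.0-fold lower number (0.00 log units; within the scatter) from compound 1 to compound 2 and a 5.6-fold higher number (0.75 log units; beyond the scatter) from compound 3 to compound 4, 5.6-fold (0.75 log units) apart, beyond the scatter of two such steps. The chloro in place of hydrogen on an aromatic carbon also depends on its partner group, giving a 3.0-fold higher number from compound 2 to compound 4 (0.48 log units; beyond the scatter): the same change on two cores in this assay, a 1.8-fold lower number (0.27 log units; within the scatter) from compound 1 to compound 3 and a 3.0-fold higher number (0.48 log units; beyond the scatter) from compound 2 to compound 4, 5.6-fold (0.75 log units) apart, beyond the scatter of two such steps. These two gaps rest on the same four compounds and are one non-additive result, which shows that the two changes do not add up here but not why, nor whether this extends beyond these compounds.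

Open, on these data alone, is whether a bromo or a methoxy in place of that chloro would behave the same way. Also open is which part of compound 4 accounts for its longer half-life.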